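The compounds below may be only part of what the source reports. "The series", "measured", "known", "first", "only" and "open" are said of these compounds alone.

Measured compounds: compound 1 `COc1cc(/C=C/C(=O)C2=C(/C=C/c3ccc(O)c(OC)c3)NC(=O)NC2c2ccccc2O)ccc1O` gives 88%; compound 2 `COc1cc(/C=C/C(=O)C2=C(/C=C/c3ccc(O)c(OC)c3)NC(=O)NC2c2ccc(O)cc2)ccc1O` gives 86.2%; compound 3 `COc1cc(/C=C/C(=O)C2=C(/C=C/c3ccc(O)c(OC)c3)NC(=O)NC2c2cccc([N+](=O)[O-])c2)ccc1O` gives 48%.

All three were tested in a functional assay, with a stated time of 20 min, tested at 50 uM; a lower number here means a weaker effect, a higher number a stronger effect of the compound at the concentration tested. Compound 3 stands lowest of the three numbers; compound 2 is nearest and compound 1 furthest, both beyond the scatter. Compound 4 `COc1cc(/C=C/C(=O)C2=C(/C=C/c3ccc(O)c(OC)c3)NC(=O)NC2c2ccccc2Cl)ccc1O` differs from compound 3 by 2-chlorophenyl in place of 3-nitrophenyl on a saturated ring carbon. Going by the values given here, the steps that bear on this are a number 40 percentage points lower from compound 1 to compound 3 (beyond the scatter) and a number 38.2 percentage points lower from compound 2 to compound 3 (beyond the scatter), both large, while a number 1.8 percentage points lower from compound 1 to compound 2 (within the scatter) shows the two hydroxyphenyl groups giving numbers within the scatter of each other. Among the compounds with values here, no measured compound carries a chlorophenyl group, so the direction is uncertain, but a partial return toward the hydroxyphenyl compounds is expected, with the expected step being a number 20 percentage points higher from compound 3 to compound 4 (beyond the scatter). The estimate for compound 4 in this assay is 68%, in the range 45% to 90%.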

Compound 4, a percentage reported as activity, at one concentration (the size of the read-out at that concentration, not a potency): 56%
Beside the measured number, compound 4's estimate is 12 percentage points above it, and the stated range covers the measured number.
By their numbers in this assay, from the lowest: compounds 3 and 4 (each within the scatter of the next); then compounds 2 and 1 (each within the scatter of the next).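

In this assay, 2-chlorophenyl and 3-nitrophenyl cannot be told apart at this saturated ring carbon, with a number 8 percentage points higher from compound 3 to compound 4 (within the scatter). Both hydroxyphenyl compounds remain clearly separate from compound 4, with a number 30.2 percentage points lower from compound 2 to compound 4 (beyond the scatter) and a number 32 percentage points lower from compound 1 to compound 4 (beyond the scatter), so the lower numbers are not confined to the nitro compound, and replacing one hydroxy with chloro is enough to produce the large step. No evidence at hand explains this gap. The compounds shown leave open whether an amino group or a carboxylic acid in place of that hydroxy would keep the higher numbers.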